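Triazole series: heptyl to 4-methoxyphenyl at the ring carbon

This account rests on a few compounds, and the source may have more. Where it says the series, first, only, none or still open, it means among the compounds named here.

Measured so far:
compound 1 `CCCCCCOc1ccc(-n2cnnc2)cc1`: 9.8 mg/kg
compound 2 `CCCCCCCc1nncn1-c1ccc(OCCCCCC)cc1`: > 40 mg/kg

In a functional assay on the whole organism (strain C57B/6) with Mus musculus as the target, in the maximal electroshock model (on this read-out lower numbers stand for an effect already at smaller amounts and higher numbers for an effect only at larger amounts of compound), compound 1 gives 9.8 mg/kg. Compound 2 returns only a limit of the assay, > 40 mg/kg, and stands at the limit of > 40 mg/kg in this assay, at which 1 of the 2 values shown sits, so its true number is not known. For the measured compounds named here, the single step measured, an at least 4.0-fold higher number from compound 1 to compound 2 (0.61 log units; beyond the scatter), is the only one that bears on the change now considered.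

Compound 3 `CCCCCCOc1ccc(-n2cnnc2-c2ccc(OC)cc2)cc1` differs from compound 2 by 4-methoxyphenyl in place of heptyl on an aromatic carbon. The measured step shows that putting heptyl on this aromatic carbon in place of hydrogen gave a higher number; nothing shows how a 4-methoxyphenyl on the same carbon compares with either. Compound 3 is therefore estimated to lie between the two measured compounds, at 25 mg/kg, within 8 mg/kg to 80 mg/kg. The expected step is an at least 1.6-fold lower number from compound 2 to compound 3 (0.20 log units; that floor lies within the scatter), with a fair chance that again only a limit is reported.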

Compound 3, dose for half-maximal effect: 15.8 mg/kg
Compound 3: the middle estimate sits 1.6-fold (0.20 log units) above what was measured; low and high end bracket the measured number.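

On the aromatic carbon between two ring nitrogen atoms, the higher number seen with heptyl does not extend to every group: in this assay, 4-methoxyphenyl in place of heptyl gives an at least 2.5-fold lower number from compound 2 to compound 3 (0.40 log units; beyond the scatter) and so recovers much of what heptyl lost. From the compounds shown here alone, compound 2 stays a limit of the assay at > 40 mg/kg and not a number, so the true size of that step is unknown. Against hydrogen on the same carbon, the reading is a 1.6-fold higher number from compound 1 to compound 3 (0.21 log units; within the scatter) and thus shows that this position accepts 4-methoxyphenyl with no change that can be told apart.

The compounds shown leave open whether the ring of the new group or its methoxy oxygen carries this result. Plain phenyl, 4-hydroxyphenyl, a shorter chain such as butyl or an amine on this carbon would help to separate these.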